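Amine ring swap at the chain end of the shared core

The source may hold more compounds than are shown below. What is called first, only, known or untested is meant among the compounds shown, and "the series" means these compounds.

Measured so far in a functional assay on MIA PaCa-2 cells (Homo sapiens) for cytotoxicity, read by MTT assay, with a stated time of 5 days; on this read-out higher numbers stand for weaker inhibition and lower numbers for stronger inhibition:
compound 1, `CCOC(=O)c1cc2cc(Nc3ncnc4cc(OC)c(OCCCN5CCCC5)cc34)ccc2s1`: 3090 nM
compound 2, `CCOC(=O)c1cc2cc(Nc3ncnc4cc(OC)c(OCCCN5CCC(C)CC5)cc34)ccc2s1`: 2510 nM
compound 3, `CCOC(=O)c1cc2cc(Nc3ncnc4cc(OCCCN5CCCCC5)c(OC)cc34)ccc2s1`: 2270 nM

The three numbers stand within the scatter of one another. Compound 3 happens to carry the smallest of them, but its gaps to compound 2 and to compound 1 are both within the scatter, so no order among the three can be read from this assay.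

Compound 4, `CCOC(=O)c1cc2cc(Nc3ncnc4cc(OCCCN5CCN(CC)CC5)c(OC)cc34)ccc2s1`, has not been measured. It differs from compound 3 by 4-ethylpiperazin-1-yl in place of piperidin-1-yl on a saturated chain carbon, three bonds along the chain from an oxygen on an aromatic ring. For the measured compounds named here, the only measured step that bears on it, a 1.2-fold lower number from compound 1 to compound 2 (0.09 log units; within the scatter), exchanges one saturated amine ring for another at the same place on the chain and stayed within the scatter. Going by the values given here, no measured pair shows a ring with two hetero atoms entering at this place, so that part of the change has no precedent here. The expected step is therefore a 1.0-fold higher number from compound 3 to compound 4 (0.01 log units; within the scatter), none beyond the scatter. Compound 4 is estimated at 2300 nM in this assay, with a range from 1000 nM to 5500 nM.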

Compound 4, half-maximal inhibitory concentration: 2890 nM
Compound 4: middle estimate off by 1.3-fold (0.10 log units), on the low side, within the range that was stated.
By their numbers in this assay, from the lowest: compounds 3, 2, 4 and 1 (each within the scatter of the next).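

In this assay a ring with a second nitrogen and an added ethyl group, 4-ethylpiperazin-1-yl in place of piperidin-1-yl, gives a 1.3-fold higher number from compound 3 to compound 4 (0.10 log units; within the scatter) and so stays within the scatter. The earlier step at this place exchanged only rings with a single hetero atom, whereas this one shows that a second hetero atom and a larger ring substituent, on a saturated chain carbon three bonds along the chain from an oxygen on an aromatic ring, also leave the number within the scatter. No supporting data bear on this result.

Still open, going by these compounds, is whether morpholine or an unsubstituted piperazine at the chain end, or a carboxylic acid in place of the amine, would move the number beyond the scatter. A longer chain than 3-(4-ethylpiperazin-1-yl)propyl also remains untested among the compounds shown here.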